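A Cyclic Amine Replaces Dipropylamino on the Shared Core

The source may hold more compounds than are shown below. What is called first, only, known or untested is meant among the compounds shown, and "the series" means these compounds.

Compound 2 `CCCN(CCC)c1nc(C(F)(F)F)ccc1CNC(=O)C(C)c1ccc(NS(C)(=O)=O)c(F)c1` holds the lowest of the two numbers measured in a functional assay on CHO-K1 cells for antagonist activity at transient receptor potential cation channel subfamily V member 1 (Homo sapiens), read by FLIPR; a higher number here means a weaker inhibitor, a lower number a stronger inhibitor; in this assay compound 2 gives 0.2 nM. Its nearest neighbour, compound 1 `CC(C(=O)NCc1ccc(C(F)(F)F)nc1Nc1ccccc1)c1ccc(NS(C)(=O)=O)c(F)c1`, gives 59.6 nM, and the step of a 300-fold lower number from compound 1 to compound 2 (2.47 log units; beyond the scatter) records the exchange of an anilino group for dipropylamino at the same aromatic carbon.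

Compound 3 `CC(C(=O)NCc1ccc(C(F)(F)F)nc1N1CCC(C)(C)CC1)c1ccc(NS(C)(=O)=O)c(F)c1` is not yet measured. It differs from compound 2 by 4,4-dimethylpiperidin-1-yl in place of dipropylamino on an aromatic carbon. Among the measured compounds shown here, the only measured step touching this position is a 300-fold lower number from compound 1 to compound 2 (2.47 log units; beyond the scatter), which was large, but it exchanged an anilino for a dialkylamino group, whereas here one dialkylamino group gives way to another that is cyclic. For the measured compounds named here, no measured pair shows such a swap. The step from compound 2 to compound 3 is therefore expected to be a 2.5-fold higher number from compound 2 to compound 3 (0.40 log units; beyond the scatter), within the scatter or at most a modest rise. Compound 3 is estimated at 0.5 nM, with a range from 0.1 nM to 3 nM.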

Compound 3, inhibition constant: 0.3 nM
Compound 3: the middle estimate sits 1.7-fold (0.22 log units) above what was measured, within the range that was stated.
By their numbers in this assay, from the lowest: compounds 2 and 3 (each within the scatter of the next); then compound 1.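

Exchanging dipropylamino for 4,4-dimethylpiperidin-1-yl on this aromatic carbon, next to the ring nitrogen, leaves the reading in this assay within the scatter (a 1.5-fold higher number from compound 2 to compound 3 (0.18 log units; within the scatter)), so the open chains and this six-membered ring cannot be told apart here. The large step away from anilino also recurs with the ring (a 200-fold lower number from compound 1 to compound 3 (2.30 log units; beyond the scatter)), which shows that it is not confined to dipropylamino. No measurement shown here offers an explanation for either step.

The compounds shown leave open whether a smaller ring such as pyrrolidine, or a ring carrying a second hetero atom such as morpholine, would stay level with compound 2 and compound 3. Also open, from the compounds shown here alone, is how shorter chains, as in dimethylamino or diethylamino, would read at this position.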